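A few compounds are considered here, and "the series" means these few. Any claim that something is new, unique, unknown or untested is made for them only; others in the source may bear on it.

Measured in an assay on isolated protein for inhibition of glucose-6-phosphatase catalytic subunit 1 (Homo sapiens), read by inositol phosphate accumulation, with a stated time of 30 min, tested at 100 uM; a lower number here means less inhibition, a higher number more inhibition at the concentration tested (going by the name of the read-out):
compound 1 `O=C1CCCC2=C1C(c1ccc(F)cc1)C=C(c1ccccc1)N2`: 21.9%
compound 2 `Cc1ccc(C2=CC(c3ccccc3)C3=C(CC(C)(C)CC3=O)N2)cc1`: "not active" (no number reported)
compound 3 `CCOC(=O)C1(O)CC(c2ccccc2)C2=C(CC(C)(C)CC2=O)O1`: "not active" (no number reported)

For the measured compounds named here, compound 1 stands as the only entry with a number. Compound 2 carries no number, only the note that it showed no activity. Compound 3 likewise carries no number. Going by the values given here, no two measured compounds differ in a single place, so no step between measured compounds can be read off.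

Compound 4 `O=C1CCCC2=C1C(c1ccccc1)C=C(c1ccccc1)N2` is the next entry. It differs from compound 1 by hydrogen in place of fluoro on an aromatic carbon; fluoro leaves and hydrogen enters on an aromatic carbon of the six-membered aromatic ring of carbon only.

Among the compounds with values here, with no comparable step in hand, the step from compound 1 to compound 4 is expected to be small, a number 3.9 percentage points lower from compound 1 to compound 4 (within the scatter), not clearly beyond the scatter, if anything slightly downward. Compound 4 is estimated at 18% in this assay, with a range from 5% to 32%; a report with no number is also a real possibility.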

Compound 4, a percentage reported as inhibition, at one concentration (the size of the read-out at that concentration, not a potency): "not active" (no number reported)
No number was reported for compound 4; there is nothing to compare the estimate with.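

For the compounds shown here, compound 4 carries only a "not active" note, so no step from compound 1 to compound 4 can be read. The compounds shown leave open whether 4-fluorophenyl to phenyl truly changes inhibition. No evidence on hand bears on this result.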